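The compounds below may be only part of what the source reports. "The series", "measured", "known", "first", "only" and "open" are said of these compounds alone.

In an ADME assay on L6 cells (Rattus norvegicus) for inhibition, read by resazurin assay, with a stated time of 72 h (a higher number here means a weaker inhibitor, a lower number a stronger inhibitor), compound 2 `CC(=O)NC[C@H]1O[C@@H](n2cnc3c(N)nc(F)nc32)[C@H](O)[C@@H]1O` stands at 182000 nM and compound 1 `[N-]=[N+]=NC[C@H]1O[C@@H](n2cnc3c(N)nc(Cl)nc32)[C@H](O)[C@@H]1O` stands at 155000 nM in the same read-out. These two values lie within the usual scatter of each other, so neither compound can be called the more potent. Both are very weak on these cells, since a higher number means weaker inhibition.

Compound 3 `CC(=O)NC[C@H]1O[C@@H](n2cnc3c(N)nc(Cl)nc32)[C@H](O)[C@@H]1O` keeps all of compound 2 except for one atom: chloro in place of fluoro on an aromatic carbon That is, the swap lies between two ring nitrogen atoms.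

Among the compounds with values here, no measured pair shows this swap on its own. Within the data shown here, compound 1 also carries chloro, but it differs from compound 2 elsewhere as well, so the value of compound 1 at 155000 nM says only that one chloro compound has been seen at this level. With so little to go on, no change beyond the scatter is expected, and no firm direction. The expected change is a 1.2-fold lower number from compound 2 to compound 3 (0.08 log units; within the scatter) and this estimate stays within the scatter. Compound 3 is expected at about 150000 nM with an estimated range of 70000 nM to 300000 nM when it is tested.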

Compound 3, half-maximal inhibitory concentration: 189000 nM
Estimate against measurement, compound 3: 1.3-fold (0.10 log units) below; low and high end bracket the measured number.
By their numbers in this assay, from the lowest: compounds 1, 2 and 3 (each within the scatter of the next).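

In this assay, the swap of fluoro for chloro on the aromatic carbon between two ring nitrogen atoms can now be read on its own: the result is a 1.0-fold higher number from compound 2 to compound 3 (0.02 log units; within the scatter) and lies within the scatter, so these two halogens cannot be told apart at this position. A second single change can also be read, acetamido in place of azido on a saturated chain carbon bound to a saturated ring carbon, with chloro kept on the aromatic carbon: this gives a 1.2-fold higher number from compound 1 to compound 3 (0.09 log units; within the scatter) and again lies within the scatter, so these two groups cannot be told apart on these cells either. No measurement at hand offers an explanation for these results.

On these data alone, both changes are swaps among a few groups, so it remains open whether any change at these two places can move the number beyond the scatter. A methoxy group in place of the halogen, or a carboxylic acid or a longer chain in place of acetamido, would test each place further, and a number beyond the scatter would show that the place matters in this assay.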